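Chalcone series: removing methoxymethoxy from compound 2

This account rests on a few compounds, and the source may have more. Where it says the series, first, only, none or still open, it means among the compounds named here.

Among the measured compounds shown here, compound 1 `COCOc1ccc(C(=O)/C=C/c2ccc(OCOC)c(CC=C(C)C)c2)c(O)c1` and compound 2 `COCOc1ccc(/C=C/C(=O)c2ccc(OC)cc2O)cc1CC=C(C)C` are the two measured members. In an assay on isolated protein for inhibition of Aromatase (Homo sapiens) (on this read-out higher numbers stand for weaker inhibition and lower numbers for stronger inhibition), compound 1 gives only a limit, > 242000 nM. In this assay compound 2 likewise gives only a limit, > 261000 nM. Both results are limits (the limit of > 242000 nM in this assay, at which 1 of the 2 values shown sits, (the limit of > 261000 nM in this assay, at which 1 of the 2 values shown sits)), so compound 2 stands at the edge of what this assay reports, with no numbered value behind it.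

Compound 3 `COc1ccc(C(=O)/C=C/c2cccc(CC=C(C)C)c2)c(O)c1` is not yet measured and differs from compound 2 by hydrogen in place of methoxymethoxy on an aromatic carbon. For the measured compounds named here, the only measured step, a step that the two limits leave unreadable from compound 1 to compound 2, is unreadable in size and alters a different part of the molecule, so it offers no sized guide to this change. With compound 2 at a limit, the step from compound 2 to compound 3 is expected to be unreadable as well, an at least 1.3-fold lower number from compound 2 to compound 3 (0.11 log units; that floor lies within the scatter). Compound 3 is expected to give about 200000 nM in this assay, within 50000 nM to 500000 nM, most likely reported as a limit.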

Compound 3, half-maximal inhibitory concentration: > 310000 nM
Compound 3: no number, only a limit (the forecaster's own chance of this, stated with the estimate: 70%); middle value at least 1.5-fold (0.19 log units) from the limit.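

In this assay compound 3 gives > 310000 nM, which is a limit. Compound 2 also stands at a limit, so the step between compound 2 and compound 3 cannot be read. The compounds shown leave open how large any effect of removing methoxymethoxy is, and whether any chalcone here gives a numbered value.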